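A few compounds are considered here, and "the series" means these few. Any claim that something is new, unique, unknown or untested is made for them only; others in the source may bear on it.

Working notes on the series.

Of the compounds shown here, two have a number so far. Compound 1 `O=C(CSc1nnc(-c2ccncc2)o1)N/N=C/c1ccc(Br)cc1` in a functional assay on HepG2 cells (Homo sapiens) for cytotoxicity, read by MTT assay, with a stated time of 48 h (a higher number here means a weaker inhibitor, a lower number a stronger inhibitor), gives 18600 nM. Among the measured compounds shown here, compound 2 `COc1cccc(/C=N/NC(=O)CSc2nnc(-c3ccncc3)o2)c1` in this assay gives 9170 nM, the lowest of the two numbers; its nearest neighbour is compound 1, and the step of a 2.0-fold lower number from compound 1 to compound 2 (0.31 log units; beyond the scatter) is the one measured step in the set.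

Compound 3 `O=C(CSc1nnc(-c2ccncc2)o1)N/N=C/c1cc(Br)cc(Br)c1O` has not been measured. It differs from compound 2 in one place: 3,5-dibromo-2-hydroxyphenyl in place of 3-methoxyphenyl on a carbon with a double bond to nitrogen. For the measured compounds named here, only the step from compound 1 to compound 2 bears on this change, and only in part, since it swapped a bromine-bearing phenyl for a methoxyphenyl and gave a modest shift. Going by the values given here, the new change removes the methoxy group and brings in two bromines and a hydroxyl on the same ring, so there is no measured step that covers the added hydroxyl at all. The expectation is therefore a step of a 1.3-fold higher number from compound 2 to compound 3 (0.12 log units; within the scatter) in this assay that stays close to the scatter, leaning toward a somewhat higher number. Compound 3 is expected to give 12000 nM in this assay, with a range from 4500 nM to 32000 nM.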

Compound 3, half-maximal inhibitory concentration: 6540 nM
Estimate against measurement, compound 3: 1.8-fold (0.26 log units) above; low and high end bracket the measured number.
By their numbers in this assay, from the lowest: compounds 3 and 2 (each within the scatter of the next); then compound 1.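

In this assay, 3,5-dibromo-2-hydroxyphenyl and 3-methoxyphenyl on a carbon with a double bond to nitrogen are not told apart, with a 1.4-fold lower number from compound 2 to compound 3 (0.15 log units; within the scatter), even though the entering group carries a hydrogen-bond donor and the leaving group carries none. Set against 4-bromophenyl, the same group gives a 2.8-fold lower number from compound 1 to compound 3 (0.45 log units; beyond the scatter), so 3,5-dibromo-2-hydroxyphenyl joins 3-methoxyphenyl as a second group at this place that stands apart from 4-bromophenyl, and bromine on the ring does not by itself go with the highest number, as compound 3 carries bromine too. No measurement is at hand that would explain either step.

On these data alone, the two bromines and the hydroxyl enter together in compound 3, so the share of each stays open, and a plain 2-hydroxyphenyl or 3,5-dibromophenyl group would be needed to separate them. Among the compounds shown here, all the groups at this place so far are substituted phenyl rings, so it also remains open how the series responds to a ring bearing a dimethylamino group or a carboxylic acid, or to a longer alkyl chain in place of the ring.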